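A few compounds are considered here, and "the series" means these few. Any claim that something is new, unique, unknown or untested is made for them only; others in the source may bear on it.

Compound 1 `Oc1cccc(-c2cc(-c3ccccc3)cc(-c3cccs3)n2)c1` gives 18900 nM in a functional assay on DU-145 cells (Homo sapiens) for cytotoxicity, read by ELISA, with a stated time of 2 days; a lower number here means a stronger inhibitor, a higher number a weaker inhibitor.
Compound 2 `Oc1ccc(-c2cc(-c3ccccc3)cc(-c3cccs3)n2)cc1` gives 3700 nM in this assay.

Compound 2 stands lowest of the two numbers measured; the step of a 5.1-fold lower number from compound 1 to compound 2 (0.71 log units; beyond the scatter) separates it from compound 1 and lies beyond the scatter.

Compound 3 `Oc1ccc(-c2cc(-c3ccccc3)cc(-c3cccnc3)n2)cc1` keeps the 4-hydroxyphenyl group of compound 2 and differs from it by pyridin-3-yl in place of thiophen-2-yl on an aromatic carbon. Among the compounds with values here, no measured step bears on this change: the only step available, from compound 1 to compound 2, concerns the hydroxyphenyl group, and the thiophen-2-yl group is shared by both measured compounds. The expectation for compound 3 therefore rests on compound 2 alone, and a small weakening is expected in this assay, giving an expected step of a 1.6-fold higher number from compound 2 to compound 3 (0.21 log units; within the scatter). Compound 3 is expected to give 6000 nM, within a range from 1500 nM to 25000 nM.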

Compound 3, half-maximal inhibitory concentration: 8400 nM
For compound 3 the middle estimate is 1.4-fold (0.15 log units) below the measured one; the measured number falls inside the stated range.
By their numbers in this assay, from the lowest: compound 2; then compound 3; then compound 1.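

Within the data shown here, this is the first reading of the position next to the ring nitrogen. With the 4-hydroxyphenyl group held fixed, pyridin-3-yl in place of thiophen-2-yl gives a 2.3-fold higher number from compound 2 to compound 3 (0.36 log units; beyond the scatter) in this assay, so the group at this position affects the number, and of these two groups thiophen-2-yl gives the lower one. The change replaces a five-membered aromatic ring holding sulfur with a six-membered one holding nitrogen, so the step cannot be divided between ring size and hetero atom, and no measurement here explains it.

The compounds shown leave open whether furan-2-yl, which keeps the five-membered ring, or pyridin-2-yl, which moves the nitrogen, would come closer to thiophen-2-yl. They also leave open how an amine at this position would read, and whether the step would recur with the 3-hydroxyphenyl group of compound 1.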